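This account rests on a few compounds, and the source may have more. Where it says the series, first, only, none or still open, it means among the compounds named here.

Compound 1 `Cc1cccc(NS(=O)(=O)c2ccc(N3CCNC3=O)cc2)c1` gives 250 nM
Compound 2 `Cc1ccc(C)c(NS(=O)(=O)c2ccc(N3CCNC3=O)cc2)c1` gives 79 nM

Going by the values given here, in a functional assay on P388D1 cells (Homo sapiens) for antiproliferative activity, read by sulforhodamine B assay, with a stated time of 48 h (a lower number here means a stronger inhibitor, a higher number a weaker inhibitor), compound 2 holds the lower of the two numbers, and compound 1 is its only neighbour on the scale. Compound 3 `O=C1NCCN1c1ccc(S(=O)(=O)Nc2cccc(Cl)c2)cc1` has not yet been measured. It differs from compound 2 by 3-chlorophenyl in place of 2,5-dimethylphenyl on a sulfonamide nitrogen while the shared core stays as it is.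

Among the compounds with values here, only one measured step bears on this change, and only in part. That step is a 3.2-fold lower number from compound 1 to compound 2 (0.50 log units; beyond the scatter) and it came with methyl in place of hydrogen on an aromatic carbon. Going to compound 3 removes the methyl groups, so part of that modest gain may be lost. Within the data shown here, no measured compound carries chlorine, so that part of the change has no measured guide. The expectation therefore leans on compound 1 at 250 nM as the nearest reference. A modest move toward a higher number is expected, estimated as a 2.5-fold higher number from compound 2 to compound 3 (0.40 log units; beyond the scatter) in this assay with wide uncertainty. Compound 3 is expected at about 200 nM with an estimated range of 70 nM to 550 nM in this assay for now.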

Compound 3, half-maximal inhibitory concentration: 78 nM
Beside the measured number, compound 3's estimate is 2.6-fold (0.41 log units) above it, within the range that was stated.
By their numbers in this assay, from the lowest: compounds 3 and 2 (each within the scatter of the next); then compound 1.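

In this assay, 3-chlorophenyl in place of 2,5-dimethylphenyl on a sulfonamide nitrogen gives a 1.0-fold lower number from compound 2 to compound 3 (0.01 log units; within the scatter), so a number of this size does not depend on the two methyl groups of compound 2: a ring carrying a single chlorine and no methyl stands level with it. The comparison with compound 1 makes this sharper, since chloro in place of methyl on an aromatic carbon gives a 3.2-fold lower number from compound 1 to compound 3 (0.51 log units; beyond the scatter), a step of about the same modest size as a 3.2-fold lower number from compound 1 to compound 2 (0.50 log units; beyond the scatter), so two different single changes to the ring on this nitrogen reach the same level. Nothing available explains why these two changes end up level, and the result rests on the numbers alone.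

On these data alone, whether a 2,5-dichlorophenyl group on the sulfonamide nitrogen, which would combine features of both rings, would read differently from compound 2 and compound 3 remains open. So does how far this position tolerates other kinds of group, such as a methoxy group, a carboxylic acid or an amine in place of the chlorine.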